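The compounds below may be only part of what the source reports. "The series", "measured", "known", "first", "only" and "open" are said of these compounds alone.

Compound 1 `CCOCCn1c(N2CCN(C)CC2)nc2ccccc21`: 10 nM
Compound 2 `COCCCn1c(N2CCN(C)CC2)nc2ccccc21`: 860 nM

Among these two, compound 2 gives the higher number in a functional assay on ileum for inhibition of histamine H1 receptor (Cavia porcellus); a higher number here means a weaker inhibitor, a lower number a stronger inhibitor; its only neighbour is compound 1, separated by an 86-fold higher number from compound 1 to compound 2 (1.93 log units; beyond the scatter). Compound 3 `CCSCCCn1c(N2CCN(C)CC2)nc2ccccc21` differs from compound 2 by ethylsulfanyl in place of methoxy on a saturated chain carbon, three bonds along the chain from an aromatic nitrogen. Among the measured compounds shown here, the single measured step, an 86-fold higher number from compound 1 to compound 2 (1.93 log units; beyond the scatter), was large, but it concerned ethoxy against methoxymethyl, not methoxy against ethylsulfanyl, so it bears on the present change only loosely. The step to compound 3 is therefore expected to be modest, about a 1.7-fold lower number from compound 2 to compound 3 (0.24 log units; within the scatter) in this assay. Compound 3 is estimated at 500 nM, within a range of 100 nM to 2500 nM.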

Compound 3, half-maximal inhibitory concentration: 530 nM
Compound 3: middle estimate off by 1.1-fold (0.03 log units), on the low side, within the range that was stated.
By their numbers in this assay, from the lowest: compound 1; then compounds 3 and 2 (each within the scatter of the next).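

In this assay, the end of the 3-carbon-named chain does not separate the two groups: 3-methoxypropyl and 3-(ethylsulfanyl)propyl differ by a 1.6-fold lower number from compound 2 to compound 3 (0.21 log units; within the scatter), so the sulfur-bearing, larger group is tolerated here as well as methoxy. (Ethylsulfanyl)methyl in place of ethoxy also gives a large step, a 53-fold higher number from compound 1 to compound 3 (1.72 log units; beyond the scatter), so compound 1 remains apart from both compounds with the propyl chain. Nothing available explains these steps. From the compounds shown here alone, whether ethylsulfanyl on the shorter chain would match ethoxy remains open, as does the outcome with a hydroxy group or an amine at this position.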